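Compound 4: (cyclopentylmethyl)carbamoyl in place of benzylcarbamoyl

The compounds below may be only part of what the source reports. "The series", "measured", "known", "first", "only" and "open" are said of these compounds alone.

In a functional assay on the whole organism for inhibition, with Rattus norvegicus as the target (on this read-out lower numbers stand for an effect already at smaller amounts and higher numbers for an effect only at larger amounts of compound), compound 1 `CCCCc1nc(SC)c(C(=O)C[S+](C)[O-])n1Cc1ccc(-c2ccccc2S(=O)(=O)NC(=O)NCc2ccccc2)cc1` gives 0.7 mg/kg, compound 2 `CCCCc1nc(SC)c(C(=O)C[S+]([O-])c2ccccc2)n1Cc1ccc(-c2ccccc2S(=O)(=O)NC(=O)NCc2ccccc2)cc1` gives 1.6 mg/kg and compound 3 `CCCc1nc(SC)c(C(=O)C[S+]([O-])c2ccccc2)n1Cc1ccc(-c2ccccc2S(=O)(=O)NC(=O)NCc2ccccc2)cc1` gives 0.8 mg/kg. The number for compound 3 lies within the scatter of those for both compound 1 and compound 2.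

Compound 4 `CCCc1nc(SC)c(C(=O)C[S+]([O-])c2ccccc2)n1Cc1ccc(-c2ccccc2S(=O)(=O)NC(=O)NCC2CCCC2)cc1` carries cyclopentyl in place of phenyl on a saturated chain carbon bound to an amide-type nitrogen. Neither measured step touches this place. The first, a 2.3-fold higher number from compound 1 to compound 2 (0.36 log units; beyond the scatter), is phenyl in place of methyl on a sulfur. The second, a 2.0-fold lower number from compound 2 to compound 3 (0.30 log units; within the scatter), is hydrogen in place of methyl on a saturated chain carbon. Both steps are small, but they offer only a rough idea of how far single changes move the numbers in this series, and no direction can be read for the new change. No step beyond the scatter is therefore expected in this assay, and the range is kept wide. The estimate amounts to an expected 1.3-fold higher number from compound 3 to compound 4 (0.10 log units; within the scatter). Compound 4 is estimated at 1 mg/kg, with an expected range from 0.35 mg/kg to 3 mg/kg.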

Compound 4, dose for 50% inhibition: > 3 mg/kg
Compound 4: a limit, no number (the forecaster's own chance of this, stated with the estimate: 5%); middle value at least 3.0-fold (0.47 log units) from the limit.
By their numbers in this assay, from the lowest: compounds 1, 3 and 2 (each within the scatter of the next, the first and the last beyond it). At a limit, above all of these: compound 4.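

Going by these compounds alone, this is the first change at the benzylcarbamoyl end, which compounds 1 to 3 all share, and it shows that this end is not indifferent: in this assay, cyclopentyl in place of phenyl on a saturated chain carbon bound to an amide-type nitrogen gives an at least 3.7-fold higher number from compound 3 to compound 4 (0.57 log units; beyond the scatter). For compound 4 the result is a limit and not a number: the limit of > 3 mg/kg in this assay, at which 1 of the 4 values shown sits. The exchange removes one carbon and replaces a six-membered aromatic ring with a five-membered non-aromatic ring, and on this core phenyl is preferred to cyclopentyl at this place in this read-out.

A single pair cannot separate ring size from aromatic character, so a cyclohexyl group and a pyridyl group in place of phenyl would be the informative comparisons. Going by these compounds, how far the number for compound 4 lies from that of compound 3 also remains open, as does whether the same change would behave alike with the butyl chain and methyl on sulfur of compound 1.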